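Swapping amino for hydroxy on a shared core

The source may hold more compounds than are shown below. What is called first, only, known or untested is meant among the compounds shown, and "the series" means these compounds.

Two compounds with the same core have so far been examined in an ADME assay on HUVEC cells (Homo sapiens) for cytotoxicity, read by MTT assay, with a stated time of 72 h; on this read-out lower numbers stand for stronger inhibition and higher numbers for weaker inhibition. For compound 1 (`COc1ccc(-n2ccnc2-c2cc(OC)c(OC)c(OC)c2)cc1[N+](=O)[O-]`) the entry reads "not determined" (no result reported) and offers nothing to compare. Among the measured compounds shown here, compound 2 (`COc1ccc(-n2ccnc2-c2cc(OC)c(OC)c(OC)c2)cc1N`) gives 58500 nM as the only number available, so it cannot yet be ranked against any other compound. Compound 3 (`COc1ccc(-n2ccnc2-c2cc(OC)c(OC)c(OC)c2)cc1O`) makes a single structural change (hydroxy in place of amino on an aromatic carbon): hydroxy in place of amino on an aromatic carbon, ortho to a methoxy group. The rest of the molecule stays the same. For the measured compounds named here, no measured step between closely related compounds shows how strongly the read-out responds to a change at this place, so any forecast is loose. It rests on compound 2 alone, with 58500 nM as its anchor. For an exchange of one heavy atom, no step beyond the usual scatter of repeat measurements is expected. The estimated step is a 1.5-fold lower number from compound 2 to compound 3 (0.17 log units; within the scatter) and it should be read as no clear change. In this assay compound 3 is expected to give about 40000 nM (estimated range 12000 nM to 110000 nM).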

Compound 3, half-maximal inhibitory concentration: 54200 nM
The estimate for compound 3 lay 1.4-fold (0.13 log units) below the measured number; the measured number falls inside the stated range.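

In this assay, placing hydroxy instead of amino on this aromatic carbon, ortho to a methoxy group, gives a 1.1-fold lower number from compound 2 to compound 3 (0.03 log units; within the scatter), so this exchange does not separate the two compounds on this read-out. Among the compounds shown here, this is the first step with numbers at both ends at this position, and it shows that the read-out can stay within its usual scatter when one of these two small groups replaces the other, at least on this shared core. Amino and hydroxy match in the computed counts of heavy atoms, hydrogen-bond donors and hydrogen-bond acceptors, so the pair tests only a close swap, and no supporting measurement is available to explain the result.

Steps involving compound 1, which carries a nitro group at this place, cannot be read, since its entry offers no number to compare. The compounds shown also leave open whether a group less like amino and hydroxy at this position, such as a carboxylic acid or a longer chain like ethoxy, would move the number beyond the usual scatter.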